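Working notes: chain extension from compound 1 to compound 3

The source may report more compounds than this note shows. Statements on the series, on what has been measured and on what is new or still open speak of the compounds shown alone.

Compound 1 (`CCCOP(=O)(O)OCCSC(=S)N1CCCCC1`) sits at the weak end of a functional assay on DU-145 cells (Homo sapiens) for inhibition, read by MTT assay, with stated times of 18 h and 4 h (on this read-out higher numbers stand for weaker inhibition and lower numbers for stronger inhibition), and has no exact reading there. Compound 1 gives > 100000 nM in this read-out, and that value is a limit of the assay, not a number. Within the data shown here, compound 2 (`CCCCCCCCCCCCCCCCOP(=O)(O)OCCSC(=S)N1CCN(C)CC1`) differs from the others in more than one place, so it offers no clean step. Even so, compound 2 gives a true number of 49300 nM and is the only measured anchor in the series.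

Compound 3 (`CCCCCCCCCCOP(=O)(O)OCCSC(=S)N1CCCCC1`) keeps the core of compound 1 and changes only the chain: heptyl in place of hydrogen on a saturated chain carbon, three bonds along the chain from an oxygen on an unsaturated carbon (methyl to octyl, if the same difference is cut one bond further out). Among the measured compounds shown here, no measured step covers this change, so the expectation is loose. For the measured compounds named here, it rests on the reading of compound 2 at 49300 nM as the only guide. The expected change is an at least 2.0-fold lower number from compound 1 to compound 3 (0.30 log units; that floor lies within the scatter) in this assay, modest and towards stronger inhibition. A limit reading for compound 3 also remains possible. For compound 3 the estimate is 50000 nM as a middle value, with an expected range from 15000 nM to 100000 nM on this read-out.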

Compound 3, half-maximal inhibitory concentration: 29300 nM
The estimate for compound 3 lay 1.7-fold (0.23 log units) above the measured number, within the range that was stated.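

With heptyl in place of hydrogen on a saturated chain carbon, three bonds along the chain from an oxygen on an unsaturated carbon, the series gains its first clean step in this assay, which is an at least 3.4-fold lower number from compound 1 to compound 3 (0.53 log units; beyond the scatter). Compound 1 reads > 100000 nM, which is a limit and not a number. The earlier compounds could not show that this position responds to the change at all, and the direction is now clear, towards stronger inhibition, although the true size of the step remains open, with only a floor readable: the limit of > 100000 nM in this assay, at which 1 of the 3 values shown sits.

With the chain varied in a single clean step, and with one end of that step a limit, the compounds shown do not tell whether the reading falls steadily with chain length, levels off or turns back, and a longer chain on the core of compound 1 would test this. They also leave open whether the gain depends on a plain hydrocarbon chain or would survive a chain carrying an amine or a carboxylic acid.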